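The source may report more compounds than this note shows. Statements on the series, on what has been measured and on what is new or still open speak of the compounds shown alone.

Compound 1 (`CC(C)=CCC/C(C)=C/C[C@]12C(=O)CC(=O)[C@](CC=C(C)C)(C[C@@H](CC=C(C)C)C1(C)C)C2=O`) and compound 2 (`CC(C)=CCC/C(C)=C/C[C@]12C[C@@H](CC=C(C)C)C(C)(C)[C@](CC=C(C)C)(C(=O)CC1=O)C2=O`) share one core and differ in the arrangement of their side chains. In a functional assay on SGC-7901 cells (Homo sapiens) for inhibition (on this read-out higher numbers stand for weaker inhibition and lower numbers for stronger inhibition), compound 1 gives 8.5 ug/mL and compound 2 gives 5.6 ug/mL, so these two values lie within the usual scatter of each other. Within the data shown here, compound 2 therefore stands level with compound 1 among the numbers measured so far. Compound 3 (`CC(C)=CCC/C(C)=C/C[C@@H]1C[C@@]2(C/C=C(\C)CCC=C(C)C)C(=O)CC(=O)[C@](CC=C(C)C)(C2=O)C1(C)C`) reads > 20 ug/mL, which is a limit of the assay and not a number.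

Compound 4 (`CC(C)=CCC/C(C)=C/C[C@]12C[C@@H](CC=C(C)C)C(C)(C)[C@](C/C=C(\C)CCC=C(C)C)(C(=O)CC1=O)C2=O`) is compound 2 with one change, (3-methylbut-2-en-1-yl in place of hydrogen on a saturated chain carbon bound to a double-bonded chain carbon). In words, 3-methylbut-2-en-1-yl replaces hydrogen on a saturated chain carbon bound to a double-bonded chain carbon, which extends a 3-methylbut-2-en-1-yl group to 3,7-dimethylocta-2,6-dien-1-yl.

Among the measured compounds shown here, only one measured step bears on this change. Compound 3 carries the same exchange on a different chain, and the result is an at least 3.5-fold higher number from compound 2 to compound 3 (0.55 log units; beyond the scatter), a move towards weaker inhibition that ends on a limit. A single step sets no rule, and the new chain sits elsewhere in compound 4, so a smaller move in the same direction seems the fair expectation. The estimated change is a 2.1-fold higher number from compound 2 to compound 4 (0.33 log units; beyond the scatter), towards a higher number in this assay. Compound 4 is expected at about 12 ug/mL, within an estimated range of 5.5 ug/mL to 24 ug/mL.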

Compound 4, half-maximal inhibitory concentration: > 20 ug/mL
Compound 4: no number, only a limit; the forecaster's own chance of this, stated with the estimate: 30%; middle value at least 1.6-fold (0.22 log units) from the limit.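

The exchange of hydrogen for 3-methylbut-2-en-1-yl, which turns a 3-methylbut-2-en-1-yl chain into a 3,7-dimethylocta-2,6-dien-1-yl chain, now has a second example in this assay: it gives an at least 3.5-fold higher number from compound 2 to compound 4 (0.55 log units; beyond the scatter), and also an at least 2.3-fold higher number from compound 1 to compound 4 (0.37 log units; beyond the scatter). With compound 3, the longer chain has now gone with weaker inhibition at two different chains, so the earlier move was not unique to one place, and the two results can be set side by side: the same change on two cores in this assay, an at least 3.5-fold higher number (0.55 log units; beyond the scatter) from compound 2 to compound 3 and an at least 2.3-fold higher number (0.37 log units; beyond the scatter) from compound 1 to compound 4; the limit leaves it open whether they differ Compound 4 carries a limit of the assay and not a number, so the true size of its steps cannot be read, and neither can any order between compound 3 and compound 4: the limit of > 20 ug/mL in this assay, at which 2 of the 4 values shown sit.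

The compounds shown leave open whether any chain on this carbon other than these two would return the number to the level of compound 2, for example a saturated 3-methylbutyl chain. They also say nothing on whether a chain ending in an amine or a carboxylic acid would keep or lose the inhibition seen for compound 1 and compound 2.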